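This account rests on a few compounds, and the source may have more. Where it says the series, first, only, none or still open, it means among the compounds named here.

Working notes on the sulfonamide series.

Compound 3 `COc1ccc(S(=O)(=O)NCCN2CCC(CCC(=O)c3cc(Cl)c(N)cc3OC)CC2)cc1OC` stands lowest of the three measured compounds in an assay on HEK293 cells for displacement of a labelled ligand from 5-hydroxytryptamine receptor 6 (Homo sapiens), with a stated time of 60 min, tested at 1 uM, in the presence of a further agent that is not named here (on this read-out higher numbers stand for a stronger effect at the one concentration tested and lower numbers for a weaker effect), giving 58%. Compound 1 `COc1ccc(S(=O)(=O)NCCN2CCC(CCC(=O)c3cc(Cl)c(N)cc3OC)CC2)cc1Cl` gives 85% in this assay, and compound 2 `COc1ccc(S(=O)(=O)NCCN2CCC(CCC(=O)c3cc(Cl)c(N)cc3OC)CC2)cc1Br` gives 72%. The measured steps all concern the substituent on the phenyl carried by the sulfonyl sulfur: a number 13 percentage points lower from compound 1 to compound 2 (beyond the scatter), a number 27 percentage points lower from compound 1 to compound 3 (beyond the scatter) and a number 14 percentage points lower from compound 2 to compound 3 (beyond the scatter).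

Compound 4 `COc1cc(N)c(Cl)cc1C(=O)CCC1CCN(CCNS(=O)(=O)c2cc(Br)c(N)c(Br)c2)CC1` differs from compound 3 in that place: 4-amino-3,5-dibromophenyl in place of 3,4-dimethoxyphenyl on a sulfonyl sulfur. Of the measured steps, a number 14 percentage points lower from compound 2 to compound 3 (beyond the scatter) bears most directly, since it exchanges bromo against methoxy on that ring, and its reverse points upward for compound 4. Among the measured compounds shown here, the amino group and the second bromo of compound 4 have no measured counterpart, so the expectation rests on that one step alone and is correspondingly uncertain. A rise beyond the scatter is expected, a number 12 percentage points higher from compound 3 to compound 4 (beyond the scatter), with compound 4 estimated at 70% in this assay, within a range from 48% to 88%.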

Compound 4, a percentage reported as inhibition, at one concentration (the size of the read-out at that concentration, not a potency): 83%
Estimate against measurement, compound 4: 13 percentage points below; the range from low to high includes it.
By their numbers in this assay, from the lowest: compound 3; then compound 2; then compounds 4 and 1 (each within the scatter of the next).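

In this assay, 4-amino-3,5-dibromophenyl on the sulfonyl sulfur gives a number 25 percentage points higher from compound 3 to compound 4 (beyond the scatter) and a number 11 percentage points higher from compound 2 to compound 4 (beyond the scatter), so among these compounds a high number at this position does not depend on the methoxy that compounds 1, 2 and 3 all carry on this ring. With a number 2 percentage points lower from compound 1 to compound 4 (within the scatter), compound 1 and compound 4 cannot be separated, although their rings differ in both halogen and the amino-for-methoxy exchange. No measurement at hand explains the gain in compound 4.

Going by these compounds, the amino group and the two bromo groups enter together, so their separate shares remain open, as does the reading of an aminodichlorophenyl ring or a plain aminophenyl ring here. On these data alone, all these numbers come from one concentration, so the potency of compound 1 and compound 4 also remains open.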